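Trimming a Dimethylamino to an Amino in a Urea Series

The compounds below may be only part of what the source reports. "The series", "measured", "known", "first", "only" and "open" are said of these compounds alone.

Three ureas built on a shared core have been tested in an ADME assay on HEK293 cells (Homo sapiens) for cytotoxicity, with a stated time of 72 h; a lower number here means that less compound is needed, a higher number that more compound is needed for the effect. Compound 1 `COc1ccc(NC(=O)Nc2cc(C)nc3ccccc23)cc1OC` gives only a limit of the assay, > 25000 nM. Compound 2 `Cc1cc(NC(=O)Nc2ccc(N(C)C)cc2)c2ccccc2n1` likewise reaches only a limit, > 25000 nM. Among the measured compounds shown here, compound 3 `Cc1cc(NC(=O)Nc2ccc(F)cc2F)c2ccccc2n1` is the one member that gives a number in this assay, 10000 nM. Compound 2 therefore stands at the edge of what the assay can report, since two of the three values shown sit at the limit of > 25000 nM in this assay, at which 2 of the 3 values shown sit, and only compound 3 falls inside the measurable range.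

Compound 4 `Cc1cc(NC(=O)Nc2ccc(N)cc2)c2ccccc2n1` has not yet been measured in this assay. It differs from compound 2 in a single place: amino in place of dimethylamino on an aromatic carbon. For the measured compounds named here, no pair of measured compounds that differ in one place is available here, so no measured step sets a scale for what such a change does. With compound 2 sitting at a limit, the expected step from compound 2 to compound 4 is a step that the limit leaves unreadable from compound 2 to compound 4, no larger than the usual scatter and in no particular direction. Compound 4 is accordingly expected to land at about 30000 nM, in the range from 12000 nM to 80000 nM, most likely reported again only as a limit.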

Compound 4, half-maximal effective concentration: > 25000 nM
Compound 4 was reported as a limit; the forecaster's own chance of this, stated with the estimate: 70%; the middle value does not contradict the limit.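

Compound 2 and compound 4 each give only a limit in this assay, so no size can be read for the step between them: the limit of > 25000 nM in this assay, at which 3 of the 4 values shown sit.

The compounds shown leave open whether amino in place of dimethylamino on an aromatic carbon changes the concentration needed for the effect at all, and if so, in which direction.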